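The compounds below may be only part of what the source reports. "The series", "measured", "known", "first", "only" and "open" are said of these compounds alone.

In a functional assay (aorta) with Oryctolagus cuniculus as the target (on this read-out lower numbers stand for tighter binding and higher numbers for weaker binding), compound 3 `COC(=O)c1ccc(OCCCN2CCC(C(c3ccc(F)cc3)c3ccc(F)cc3)CC2)c(OC)c1` gives 1.26 nM as its result. Compound 1 `COc1cc(C(C)=O)ccc1OCCCN1CCC(C(c2ccc(F)cc2)c2ccc(F)cc2)CC1` gives 1.59 nM and so lies within the scatter of it, while compound 2 `COc1cc(C(C)=O)ccc1OCCCN1CCC(C(c2ccccc2)c2ccccc2)CC1` gives a clearly higher 6.31 nM on the same read-out.

Compound 4 `CC(=O)c1ccc(OCCCN2CCC(C(c3ccc(F)cc3)c3ccc(F)cc3)CC2)cc1` has not been measured yet. In it, 4-acetylphenyl stands in place of 2-methoxy-4-(methoxycarbonyl)phenyl on an oxygen on a saturated carbon (4-acetylphenyl in place of 2-methoxy-4-(methoxycarbonyl)phenyl on an oxygen on a saturated carbon). Part of this change has a measured counterpart, since compound 4 carries the methyl on its carbonyl carbon where compound 3 carries a methoxy. Because that swap gave a 1.3-fold lower number from compound 1 to compound 3 (0.10 log units; within the scatter) on its own, reversing it is expected to change little. Among the measured compounds shown here, no measured step shows what losing the other methoxy does, and that gap is the main uncertainty. The expected result is a 1.6-fold higher number from compound 3 to compound 4 (0.20 log units; within the scatter) and so no step beyond the scatter in this assay as a best guess. For compound 4 the estimate is 2 nM with an expected range from 0.6 nM to 6.5 nM in repeated measurements.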

Compound 4, dissociation constant: 2.51 nM
The estimate for compound 4 lay 1.3-fold (0.10 log units) below the measured number; the measured number falls inside the stated range.
By their numbers in this assay, from the lowest: compounds 3, 1 and 4 (each within the scatter of the next); then compound 2.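

In this assay, among the compounds shown here, the change that no earlier pair isolated, hydrogen in place of methoxy on an aromatic carbon, gives a 1.6-fold higher number from compound 1 to compound 4 (0.20 log units; within the scatter), so that methoxy can go without a step beyond the scatter. The full swap to 4-acetylphenyl in place of 2-methoxy-4-(methoxycarbonyl)phenyl gives a 2.0-fold higher number from compound 3 to compound 4 (0.30 log units; within the scatter), so on this oxygen the group tolerates both the loss of that methoxy and methyl in place of the methoxy on the carbonyl carbon. No measurement here explains this tolerance.

As far as these compounds go, every group at this place still carries a carbonyl, so it remains open whether an unsubstituted phenyl, or an amine or a carboxylic acid in place of the acetyl, would stay within the scatter. A longer chain between this oxygen and the shared core is also untested among the compounds shown.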